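The compounds below may be only part of what the source reports. "The series", "measured", "known", "first", "only" and "open" are said of these compounds alone.

Measured compounds:

Compound 1, `CCOc1cc(=O)oc2cc(OCc3cccc(Cl)c3)ccc12`: 115 nM in an assay on isolated protein (strain Sprague-Dawley) for inhibition of Amine oxidase [flavin-containing] B (Rattus norvegicus), read by spectrophotometry, with a stated time of 5 min; on this read-out higher numbers stand for weaker inhibition and lower numbers for stronger inhibition
Compound 2, `CNC(=O)COc1cc(=O)oc2cc(OCc3cccc(Cl)c3)ccc12`: 33.9 nM
Compound 3, `Nc1cc(=O)oc2cc(OCc3cccc(Cl)c3)ccc12`: 47.9 nM

Compound 3 stands second highest of the three numbers in this assay. Its nearest neighbour is compound 2, which gives a number within the scatter of it; its furthest is compound 1, a step of a 2.4-fold lower number from compound 1 to compound 3 (0.38 log units; beyond the scatter) separating the two.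

Compound 4, `N#Cc1cc(=O)oc2cc(OCc3cccc(Cl)c3)ccc12`, has not yet been measured. It differs from compound 3 as follows: cyano in place of amino on an aromatic carbon.

Among the measured compounds shown here, no measured pair exchanges amino for cyano, so no step speaks directly to this change. The two steps that alter the same aromatic carbon are a 2.4-fold lower number from compound 1 to compound 3 (0.38 log units; beyond the scatter) and a 1.4-fold higher number from compound 2 to compound 3 (0.15 log units; within the scatter), the first beyond the scatter and the second within it; together they show that the three groups tried at this position all fall within a modest span of numbers in this assay. On that basis the step of a 1.3-fold higher number from compound 3 to compound 4 (0.10 log units; within the scatter) is expected to be small, with no confident direction, and a number within the scatter of compound 3 is the most likely outcome. Compound 4 is therefore estimated at 60 nM, with a range from 20 nM to 200 nM.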

Compound 4, half-maximal inhibitory concentration: 102 nM
Compound 4: the middle estimate sits 1.7-fold (0.23 log units) below what was measured, within the range that was stated.
By their numbers in this assay, from the lowest: compounds 2 and 3 (each within the scatter of the next); then compounds 4 and 1 (each within the scatter of the next).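

In this assay, cyano in place of amino on this aromatic carbon gives a 2.1-fold higher number from compound 3 to compound 4 (0.33 log units; beyond the scatter) and so shows a change beyond the scatter between two groups of few heavy atoms, whereas the earlier amino and (methylcarbamoyl)methoxy groups did not separate. Cyano in place of (methylcarbamoyl)methoxy gives a 3.0-fold higher number from compound 2 to compound 4 (0.48 log units; beyond the scatter) while cyano in place of ethoxy gives a 1.1-fold lower number from compound 1 to compound 4 (0.05 log units; within the scatter) and this divides the four compounds into a lower pair, compounds 2 and 3, and a higher pair, compounds 1 and 4. The lower pair carry a hydrogen on the nitrogen of the group at this position, as the amino hydrogens and the amide hydrogen, and the higher pair do not, but this is only a correlation across four compounds and nothing available here bears on its cause.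

Whether that hydrogen matters stays open, and a methylamino, dimethylamino or acetamido group at this carbon would separate it from the other differences among these groups. Also open, from the compounds shown here alone, is whether the step from amino to cyano holds with fluorine in place of the chlorine elsewhere in the molecule.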